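The source may hold more compounds than are shown below. What is called first, only, known or untested is meant among the compounds shown, and "the series" means these compounds.

Compound 1, `Cc1ccc(Nc2cc(NC(=O)Nc3c(Cl)cccc3Cl)ncn2)cc1C`, gives 84.3% in a functional assay on HCC827 cells (Homo sapiens) for inhibition, read by MTT assay, with a stated time of 48 h, tested at 10 uM; on this read-out higher numbers stand for more inhibition at the one concentration tested (going by the name of the read-out) and lower numbers for less inhibition.
Compound 2, `Cc1cc(F)cc(Nc2cc(NC(=O)Nc3c(Cl)cccc3Cl)ncn2)c1`, gives 49.1%.
Compound 3, `COc1ccc(Nc2cc(NC(=O)Nc3c(Cl)cccc3Cl)ncn2)cc1C`, gives 63.1%.

Compound 3 stands second highest of the three numbers in this assay: compound 1 lies above it, the step being a number 21.2 percentage points lower from compound 1 to compound 3 (beyond the scatter), and compound 2 below it, the step being a number 14 percentage points higher from compound 2 to compound 3 (beyond the scatter). The change now considered leads to compound 4, `CCc1ccc(Nc2cc(NC(=O)Nc3c(Cl)cccc3Cl)ncn2)cc1`, and is 4-ethylphenyl in place of 4-methoxy-3-methylphenyl on a nitrogen on an aromatic ring.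

For the measured compounds named here, two measured steps bear on it. The exchange of the whole aryl group on a nitrogen on an aromatic ring moved the number by a number 35.2 percentage points lower from compound 1 to compound 2 (beyond the scatter) and by a number 14 percentage points higher from compound 2 to compound 3 (beyond the scatter), so such swaps have given modest to large shifts. Compound 1, which carries only methyl groups on that ring, gave the highest number, and the step of a number 21.2 percentage points lower from compound 1 to compound 3 (beyond the scatter) shows that exchanging methyl for methoxy lowered it. Compound 4 carries only an alkyl group on that ring, so a modest rise is expected, a number 8.9 percentage points higher from compound 3 to compound 4 (within the scatter), in this assay. Compound 4 is therefore estimated at 72%, with a range from 52% to 90%.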

Compound 4, a percentage reported as inhibition, at one concentration (the size of the read-out at that concentration, not a potency): 58%
Beside the measured number, compound 4's estimate is 14 percentage points above it; the range from low to high includes it.
By their numbers in this assay, from the lowest: compounds 2, 4 and 3 (each within the scatter of the next, the first and the last beyond it); then compound 1.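

In this assay, 4-ethylphenyl on a nitrogen on an aromatic ring falls short of 3,4-dimethylphenyl (the step is a number 26.3 percentage points lower from compound 1 to compound 4 (beyond the scatter)), so among the compounds shown, an aryl group carrying only alkyl groups does not by itself give the high number of compound 1. Compound 4 cannot be told apart from either of the other two compounds (a number 5.1 percentage points lower from compound 3 to compound 4 (within the scatter); a number 8.9 percentage points higher from compound 2 to compound 4 (within the scatter)), although its aryl group has neither the methoxy of compound 3 nor the fluoro of compound 2. No measurement shown here explains this result.

The compounds shown leave open whether a longer alkyl chain, an amine or a carboxylic acid on this aryl group would bring the number back towards that of compound 1.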